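Same Atoms, One Side Chain Rearranged

A few compounds are considered here, and "the series" means these few. Any claim that something is new, unique, unknown or untested is made for them only; others in the source may bear on it.

In an ADME assay on a cell-free system (plasma, Homo sapiens) for protein binding, compound 2 `Cc1cc(Nc2ccc(C(F)(F)F)cc2)n2nc(CCO)nc2n1` gives 67%. That lies within the scatter of compound 1 `COCc1nc2nc(C)cc(Nc3ccc(C(F)(F)F)cc3)n2n1` at 75.6%, and well apart from compound 3 `Cc1cc(Nc2ccc(S(F)(F)(F)(F)F)cc2)n2nc(C3CC3)nc2n1` at 97.7%. Compound 4 `CCOc1nc2nc(C)cc(Nc3ccc(C(F)(F)F)cc3)n2n1` has the same atoms joined differently: ethoxy in place of 2-hydroxyethyl on an aromatic carbon. Among the compounds with values here, the one measured step that bears on this is a 1.4-fold higher unbound fraction from compound 1 to compound 2 (0.13 log units; within the scatter), a swap at the end of the same side chain. Compound 4 shares an ether with compound 1 at 75.6%, so no step beyond the scatter is expected in this assay, only a lean towards a lower unbound fraction. The estimated step is a 1.7-fold lower unbound fraction from compound 2 to compound 4 (0.22 log units; within the scatter). For compound 4 the expected value is 80%, with an estimated range from 66% to 91%.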

Compound 4, plasma protein binding: 92.4%
Beside the measured number, compound 4's estimate is 2.6-fold (0.42 log units) (unbound fraction) above it; the measured number lies above the stated range.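

Rearranging the same atoms at this position does shift binding in this assay: ethoxy on the aromatic carbon leaves much less compound free than 2-hydroxyethyl (a 4.3-fold lower unbound fraction from compound 2 to compound 4 (0.64 log units; beyond the scatter)). Sharing an ether does not keep the two ether compounds close either (a 3.2-fold lower unbound fraction from compound 1 to compound 4 (0.51 log units; beyond the scatter)). Among these compounds, then, where the oxygen sits in the side chain matters, whereas the earlier swap at the chain's end stayed within the scatter. Nothing available explains this shift. From the compounds shown here alone, whether an amine or a longer chain such as propoxy on this carbon would bind like ethoxy remains open.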